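The source may hold more compounds than are shown below. What is called first, only, known or untested is meant among the compounds shown, and "the series" means these compounds.

Within the data shown here, compound 2 `Cc1c(S(=O)(=O)c2ccccc2)c2cccnc2n1CCN` is one of two compounds measured in a functional assay on HeLa cells for agonist activity at 5-hydroxytryptamine receptor 6 (Homo sapiens), read by immunoassay; on this read-out higher numbers stand for an effect only at larger amounts of compound and lower numbers for an effect already at smaller amounts. In this assay compound 2 gives 20 nM, the lowest of the two numbers, while compound 1 `CN(C)CCn1cc(S(=O)(=O)c2ccccc2)c2cccnc21` gives 25 nM; the two numbers lie within the scatter of each other, so nothing separates them. Compound 3 `Cc1c(S(=O)(=O)c2ccccc2)c2cccnc2n1CCN(C)C` has not yet been measured in this assay. It differs from compound 2 in one place: dimethylamino in place of amino on a saturated chain carbon, two bonds along the chain from an aromatic nitrogen. Among the measured compounds shown here, no step between measured compounds shows what this change does on its own. Compound 1 also carries a 2-(dimethylamino)ethyl chain and sits within the scatter of compound 2, so no step beyond the scatter is expected in either direction. Compound 3 is therefore expected to give about 15 nM, with a range from 5 nM to 50 nM, which means an expected step of a 1.3-fold lower number from compound 2 to compound 3 (0.12 log units; within the scatter).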

Compound 3, half-maximal effective concentration: 47 nM
For compound 3 the middle estimate is 3.1-fold (0.50 log units) below the measured one; the measured number falls inside the stated range.
By their numbers in this assay, from the lowest: compounds 2, 1 and 3 (each within the scatter of the next, the first and the last beyond it).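

In this assay, dimethylamino in place of amino on a saturated chain carbon, two bonds along the chain from an aromatic nitrogen, now has a step of its own: a 2.4-fold higher number from compound 2 to compound 3 (0.37 log units; beyond the scatter), modest but beyond the scatter, so this change is not neutral here, which compound 1 alone could not show. Methyl in place of hydrogen on an aromatic carbon gives a 1.9-fold higher number from compound 1 to compound 3 (0.27 log units; within the scatter), which stays within the scatter, so with the 2-(dimethylamino)ethyl chain in place the methyl does not separate the two compounds. No measurement at hand gives a reason for the step from amino to dimethylamino.

The compounds shown leave open where methylamino would fall relative to amino and dimethylamino, and how a pyrrolidine ring at the chain end would read. They also leave open what a longer chain would do.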